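This account rests on a few compounds, and the source may have more. Where it says the series, first, only, none or still open, it means among the compounds named here.

Working notes on the series. Compound 1 `COc1cccc(Nc2nc3nonc3nc2Nc2cccc(OC)c2)c1` and compound 2 `Fc1ccccc1Nc1nc2nonc2nc1Nc1ccccc1` share one core but differ from each other in more than one place, so no single step can be read between them. In an assay on mitochondria from L6 cells (Rattus norvegicus) for activation, with a stated time of 90 min (a higher number here means that more compound is needed for the effect, a lower number that less compound is needed), compound 1 gives only a limit, > 100000 nM, and not a number. In this assay, for the measured compounds named here, compound 2 gives 2200 nM, the only full number in the set so far. The other value shown belongs to compound 1, and the limit of > 100000 nM in this assay, at which 1 of the 2 values shown sits, marks where it sits, so compound 2 has no measured neighbour to place it against. Compound 3 `Fc1ccc(Nc2nc3nonc3nc2Nc2ccccc2F)cc1` is the next point: fluoro in place of hydrogen on an aromatic carbon. Read one bond further out, the change turns phenyl into 4-fluorophenyl and anilino into (4-fluorophenyl)amino, on the ring that carried no fluorine in compound 2. Going by the values given here, no measured step in the set matches this change, so the expectation rests on the small size of the change alone: a step from compound 2 to compound 3 no larger than the scatter of this assay is expected, a 1.1-fold lower number from compound 2 to compound 3 (0.04 log units; within the scatter). Compound 3 is accordingly estimated at about 2000 nM in this assay, with a range of 700 nM to 6000 nM.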

Compound 3, half-maximal effective concentration: 2300 nM
Compound 3: middle estimate off by 1.2-fold (0.06 log units), on the low side; measured number inside the range.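

In this assay, fluoro in place of hydrogen on an aromatic carbon, para to a large group, gives a 1.0-fold higher number from compound 2 to compound 3 (0.02 log units; within the scatter) and so leaves no readable change at this position on the ring that carried no fluorine in compound 2. For the compounds shown here, this is the first step that can be read, and it shows that this position accepts 4-fluorophenyl in place of phenyl with the number staying within the scatter; the steps from compound 1 to compound 2 and to compound 3 cannot be read, since compound 1 differs from each in more than one place. Nothing measured here gives a cause for this result.

Still open is whether a larger or charged group at this place, such as trifluoromethyl, an amine or a carboxylic acid, would move the number beyond the scatter, since fluoro is the only replacement of hydrogen shown here. Also open, as far as these compounds go, is which of the several differences separates compound 1, which gives only a limit, from compound 2 and compound 3.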